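This account rests on a few compounds, and the source may have more. Where it says the series, first, only, none or still open, it means among the compounds named here.

Compound 1 `CCCc1ccc(O)c(-c2ccn(CCC)n2)c1`: 91300 nM
Compound 2 `CCCn1ccc(-c2cc(CC)ccc2O)n1`: > 200000 nM, a limit of the assay
Compound 3 `CCCc1ccc(O)c(-c2cc[nH]n2)c1`: not yet measured

Among the compounds with values here, in a functional assay on BV-2 cells (Mus musculus) for inhibition, read by Griess assay, with a stated time of 24 h (a lower number here means a stronger inhibitor, a higher number a weaker inhibitor), compound 1 gives 91300 nM, the only true number so far. The next change is hydrogen in place of propyl on an aromatic nitrogen, in words hydrogen in place of propyl on an aromatic nitrogen. Within the data shown here, only one measured step bears on it, and indirectly, since it lies at another place: an at least 2.1-fold higher number from compound 1 to compound 2 (0.34 log units; beyond the scatter). From that modest loss, a step towards a higher number, meaning a weaker inhibitor, is expected. The expected size is a 1.6-fold higher number from compound 1 to compound 3 (0.22 log units; within the scatter). Compound 3 is estimated at 150000 nM, within 60000 nM to 350000 nM.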

Compound 3, half-maximal inhibitory concentration: 60200 nM
Compound 3: middle estimate off by 2.5-fold (0.40 log units), on the high side; the measured number falls inside the stated range.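

In this assay, hydrogen in place of propyl on the aromatic nitrogen gives a 1.5-fold lower number from compound 1 to compound 3 (0.18 log units; within the scatter), so the propyl on this nitrogen is not required for the weak inhibition of compound 1. This position therefore tolerates the loss of the whole chain, unlike the saturated chain on the other ring position, where shortening already cost activity. Compound 2 remains a limit and not a number: the limit of > 200000 nM in this assay, at which 1 of the 3 values shown sits.

Still open, going by these compounds, is whether a methyl, a longer chain or a chain bearing an amine on this nitrogen would move the number beyond the scatter.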